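Swapping the aryl on the pyridazinone: a small step

The compounds below may be only part of what the source reports. "The series", "measured", "known", "first", "only" and "open" are said of these compounds alone.

Measured compounds:
- compound 1, `COc1cc2c(Oc3ccc(NC(=O)c4nn(-c5ccccc5)c(=O)cc4C)cc3F)ccnc2cc1OCCCN1CCCC1`: 220 nM
- compound 2, `COc1cc2c(Oc3ccc(NC(=O)c4nn(-c5ccc(Cl)cc5)c(=O)cc4C)cc3F)ccnc2cc1OCCCN1CCCC1`: 260 nM

Both compounds were tested in a functional assay on HT-29 cells (Homo sapiens) for inhibition, read by MTT assay, with a stated time of 72 h; a higher number here means a weaker inhibitor, a lower number a stronger inhibitor. Compound 1 gives 220 nM, and compound 2 gives 260 nM. Of the two numbers, compound 2 has the higher one, yet a 1.2-fold higher number from compound 1 to compound 2 (0.07 log units; within the scatter), so the two compounds cannot be told apart on these data.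

Compound 3, `COc1cc2c(Oc3ccc(NC(=O)c4nn(-c5ccc(F)c(F)c5)c(=O)cc4C)cc3F)ccnc2cc1OCCCN1CCCC1`, has not yet been measured. It differs from compound 2 by 3,4-difluorophenyl in place of 4-chlorophenyl on an aromatic nitrogen. Among the compounds with values here, the only measured step that bears on this position is the one from compound 1 to compound 2, where a chlorine replaced a hydrogen on that same aromatic ring: a 1.2-fold higher number from compound 1 to compound 2 (0.07 log units; within the scatter). That single step says this ring tolerates a change in its substitution without a shift beyond the scatter. A pair of fluorines is a further change of the same kind, so the expectation is a step of no more than scatter size in either direction, that is a 1.0-fold lower number from compound 2 to compound 3 (0.02 log units; within the scatter).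

On that basis compound 3 is expected to give about 250 nM, with a likely range from 120 nM to 550 nM.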

Compound 3, half-maximal inhibitory concentration: 150 nM
Compound 3: the middle estimate sits 1.7-fold (0.22 log units) above what was measured; measured number inside the range.
By their numbers in this assay, from the lowest: compounds 3, 1 and 2 (each within the scatter of the next).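

Compound 3 brings a second kind of halogen substitution to the aryl group on the aromatic nitrogen. In this assay, the exchange of 4-chlorophenyl for 3,4-difluorophenyl gives a 1.7-fold lower number from compound 2 to compound 3 (0.24 log units; within the scatter), and the exchange of phenyl for 3,4-difluorophenyl gives a 1.5-fold lower number from compound 1 to compound 3 (0.17 log units; within the scatter). Within the data shown here, three aryl groups, one bare, one with a single chlorine and one with two fluorines, have now been compared here, and every step between them stays within the scatter, so this read-out does not separate them, and the tolerance suggested by the single earlier step now holds across a wider set of halogen patterns. No measurement is available that would explain why these numbers are so close.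

On these data alone, all three groups carry only hydrogen or halogen on this ring, so it remains open whether an amine, a carboxylic acid or a methoxy group in their place would move the number beyond the scatter. It is also open whether replacing the whole aryl group with a simple alkyl chain would still be tolerated, since every compound shown keeps an aromatic ring on that nitrogen.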